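Aryl swap on compound 3: expected effect on L02 cells

This account rests on a few compounds, and the source may have more. Where it says the series, first, only, none or still open, it means among the compounds named here.

Compound 1 `Cc1ccccc1-n1nncc1CN1C(=O)C2(C(C#N)=C(N)Oc3c(N)cc4nc5ccccc5nc4c32)c2ccccc21`: in an ADME assay on L02 cells (Homo sapiens) for antiproliferative activity, read by MTT assay, with a stated time of 48 h (a lower number here means a stronger inhibitor, a higher number a weaker inhibitor), compound 1 gives > 50000 nM, a limit of the assay (the limit of > 50000 nM in this assay, at which 1 of the 3 values shown sits).
Compound 2 `CCc1ccccc1-n1nncc1CN1C(=O)C2(C(C#N)=C(N)Oc3c(N)cc4nc5ccccc5nc4c32)c2ccccc21`: compound 2 gives 22900 nM.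
Compound 3 `N#CC1=C(N)Oc2c(N)cc3nc4ccccc4nc3c2C12C(=O)N(Cc1cnnn1-c1ccccc1Br)c1ccccc12`: compound 3 gives 29200 nM.

Compound 3 holds the highest of the two numbers given; its nearest neighbour is compound 2, with a 1.3-fold higher number from compound 2 to compound 3 (0.11 log units; within the scatter). Going by the values given here, the only step beyond the scatter is an at least 2.1-fold lower number from compound 1 to compound 2 (0.33 log units; beyond the scatter), while an at least 1.7-fold lower number from compound 1 to compound 3 (0.23 log units; that floor lies within the scatter) carries a floor within it. Compound 4 `CCOc1ccc(-n2nncc2CN2C(=O)C3(C(C#N)=C(N)Oc4c(N)cc5nc6ccccc6nc5c43)c3ccccc32)cc1` differs from compound 3 by 4-ethoxyphenyl in place of 2-bromophenyl on an aromatic nitrogen. Among the compounds with values here, the three measured steps all rework the substituent of the 2-bromophenyl group that leaves here, and none of them reaches a large change, so no measured step speaks directly for this swap. Compound 4 is therefore expected to show a 1.0-fold higher number from compound 3 to compound 4 (0.01 log units; within the scatter), nothing beyond the scatter. The estimate for compound 4 is 30000 nM, between 12000 nM and 75000 nM.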

Compound 4, half-maximal inhibitory concentration: > 50000 nM
Compound 4: a limit, no number (the forecaster's own chance of this, stated with the estimate: 25%); middle value at least 1.6-fold (0.22 log units) from the limit.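

Going by these compounds alone, exchanging 2-ethylphenyl for 4-ethoxyphenyl on the aromatic nitrogen gives an at least 2.1-fold higher number from compound 2 to compound 4 (0.33 log units; beyond the scatter), the first step at this position in this assay that moves toward the weaker end, while the change from 2-bromophenyl gives an at least 1.7-fold higher number from compound 3 to compound 4 (0.23 log units; that floor lies within the scatter), whose floor does not separate the two compounds. Compound 4 is a limit, not a number, and it shares that limit with compound 1, so the step between them cannot be read: the limit of > 50000 nM in this assay, at which 2 of the 4 values shown sit.

The compounds leave open whether the ethoxy group or its place on the ring accounts for the higher number, as compound 4 differs from the others in both. On these data alone, a 2-ethoxyphenyl or 4-ethylphenyl group would separate the two, and how a 4-aminophenyl group would read also stays open.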